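Chloro on the fused ring of compound 2

A few compounds are considered here, and "the series" means these few. Any claim that something is new, unique, unknown or untested is made for them only; others in the source may bear on it.

Compound 2 `Cn1ccc2cc(-c3ccn4c(CC(F)(F)F)cnc4c3C#N)ccc21` gives the lowest number of the three in a functional assay on CHO cells for agonist activity at metabotropic glutamate receptor 2 (Homo sapiens), read by GTPgammaS binding (on this read-out lower numbers stand for an effect already at smaller amounts and higher numbers for an effect only at larger amounts of compound), 230 nM; compound 1 `N#Cc1c(-c2ccc3c(ccn3[C@H]3CC[C@H](O)CC3)c2)ccn2c(CC(F)(F)F)cnc12` gives 330 nM, a number that stays within the scatter of that of compound 2, while compound 3 `N#Cc1c(-c2ccc(OC3CCOCC3)c(Cl)c2)ccn2c(CC(F)(F)F)cnc12` gives 617 nM, a gap that lies beyond the scatter. Among the compounds with values here, the only measured step, a 1.4-fold lower number from compound 1 to compound 2 (0.16 log units; within the scatter), concerns a substituent on an aromatic nitrogen and does not touch the ring changed here. Compound 4 `Cn1ccc2cc(-c3ccn4c(CC(F)(F)F)cnc4c3C#N)cc(Cl)c21` differs from compound 2 by chloro in place of hydrogen on an aromatic carbon, on an aromatic carbon of a six-membered aromatic ring of carbon only, part of a fused system, ortho to a fused ring. Within the data shown here, compound 3 carries a chloro on a different ring and offers no step to compare. Among the measured compounds shown here, with no bearing step, compound 4 is expected to stay within the scatter, a 1.1-fold higher number from compound 2 to compound 4 (0.04 log units; within the scatter), at an estimated 250 nM (100 nM to 600 nM).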

Compound 4, half-maximal effective concentration: 120 nM
The estimate for compound 4 lay 2.1-fold (0.32 log units) above the measured number, and the stated range covers the measured number.
By their numbers in this assay, from the lowest: compounds 4, 2, 1 and 3 (each within the scatter of the next, the first and the last beyond it).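

In this assay, within the data shown here, the fused ring of compound 2 takes a chloro on the aromatic carbon ortho to a fused ring, with a 1.9-fold lower number from compound 2 to compound 4 (0.28 log units; within the scatter) as the only reading at this position. Among these compounds, this is the first step at this ring, and it shows that one chlorine here keeps the number within the scatter of the hydrogen parent. Nothing available explains the step.

Open, on these data alone, is whether a fluoro, a methoxy or an amine at this carbon would give a step beyond the scatter. Also open, as far as these compounds go, is whether the chloro behaves alike with 4-hydroxycyclohexyl on the aromatic nitrogen.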